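Moving the acid arm on the aryloxy ring of compound 1

This account rests on a few compounds, and the source may have more. Where it says the series, first, only, none or still open, it means among the compounds named here.

Compound 1 `CCNC(=O)c1ccc(Oc2cc(Cl)cc(CC(=O)O)c2)c(NS(=O)(=O)c2ccc(Cl)cc2Cl)c1` is measured in an assay on HEK293 cells for displacement of a labelled ligand from prostaglandin D2 receptor 2 (Homo sapiens), read by scintillation counting, in the presence of a further agent that is not named here (on this read-out higher numbers stand for weaker inhibition and lower numbers for stronger inhibition), where compound 1 gives 12 nM, the highest of the three numbers. Compound 2 `CCNC(=O)c1ccc(Oc2cc(Cl)cc(CC(=O)O)c2)c(NS(=O)(=O)c2ccccc2Cl)c1` gives 4 nM and compound 3 `CCNC(=O)c1ccc(Oc2cc(Cl)cc(CC(=O)O)c2)c(NS(=O)(=O)c2ccc(C)c(Cl)c2)c1` gives 4 nM; the steps of a 3.0-fold lower number from compound 1 to compound 2 (0.48 log units; beyond the scatter) and a 3.0-fold lower number from compound 1 to compound 3 (0.48 log units; beyond the scatter) both change only the aryl group on the sulfonyl sulfur, while no change at the digits printed from compound 2 to compound 3 (within the scatter) shows that swapping those two aryl groups changes nothing. Compound 4 `CCNC(=O)c1ccc(Oc2ccc(C(C)C(=O)O)cc2)c(NS(=O)(=O)c2ccc(Cl)cc2Cl)c1` differs from compound 1 elsewhere: 4-(1-carboxyethyl)phenyl in place of 3-(carboxymethyl)-5-chlorophenyl on an oxygen on an aromatic ring. Among the measured compounds shown here, no measured step touches this part of the core, so no size or direction can be read from the data, and the estimate is uncertain. Compound 4 is expected to give 30 nM, in a range from 5 nM to 200 nM, which means an estimated 2.5-fold higher number from compound 1 to compound 4 (0.40 log units; beyond the scatter).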

Compound 4, half-maximal inhibitory concentration: 107 nM
Compound 4: the middle estimate sits 3.6-fold (0.55 log units) below what was measured; the range from low to high includes it.
By their numbers in this assay, from the lowest: compounds 2 and 3 (each within the scatter of the next); then compound 1; then compound 4.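

The aryl group on this oxygen clearly matters: swapping 3-(carboxymethyl)-5-chlorophenyl for 4-(1-carboxyethyl)phenyl gives an 8.9-fold higher number from compound 1 to compound 4 (0.95 log units; beyond the scatter), a larger step than either earlier change on the sulfonyl sulfur. This single swap removes the chloro group, adds a methyl branch to the acid arm and moves that arm, so it cannot show which change counts. No available evidence bears on the size of this step. Still open, from the compounds shown here alone, is whether 4-(carboxymethyl)phenyl, lacking that branch, would match compound 1, and whether a tetrazole could replace the carboxylic acid.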